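A few compounds are considered here, and "the series" means these few. Any claim that something is new, unique, unknown or untested is made for them only; others in the source may bear on it.

Working notes on the chain-length series. In a functional assay on MOLT-3 cells (Homo sapiens) (on this read-out higher numbers stand for weaker inhibition and lower numbers for stronger inhibition), compound 1 `CCCCCCCCSC[C@H](NC(C)=O)C(=O)CCl` gives 4100 nM, and compound 3 `CCCCCCCCCCCCCCCSC[C@H](NC(C)=O)C(=O)CCl` gives 8600 nM. For compound 2 `CCCCCCCCCCCCCSC[C@H](NC(C)=O)C(=O)CCl` this assay reports only a limit, > 100000 nM. Compound 3 therefore stands highest of the two numbers shown; the gap to the nearest number is a 2.1-fold higher number from compound 1 to compound 3 (0.32 log units; beyond the scatter).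

Compound 4 `CCCCCCCCCCCCCCCCSC[C@H](NC(C)=O)C(=O)CCl` is not yet measured; it differs from compound 3 by methyl in place of hydrogen on a saturated chain carbon, ten or more bonds along the chain from a sulfur. The measured steps that bear on this change are an at least 11-fold lower number from compound 2 to compound 3 (1.06 log units; beyond the scatter), which starts from a limit, together with a 2.1-fold higher number from compound 1 to compound 3 (0.32 log units; beyond the scatter) and an at least 24-fold higher number from compound 1 to compound 2 (1.38 log units; beyond the scatter). The numbers do not run in one direction with chain length, and compound 2 goes against any simple trend, so a one-carbon extension gives little firm guidance. Given that the nearest comparison, compound 3, sits at 8600 nM, the expected step in this assay is a 1.2-fold higher number from compound 3 to compound 4 (0.07 log units; within the scatter), small and within or near the scatter. Compound 4 is expected at 10000 nM, with a range from 3000 nM to 60000 nM.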

Compound 4, half-maximal inhibitory concentration: 17300 nM
Estimate against measurement, compound 4: 1.7-fold (0.24 log units) below; measured number inside the range.
By their numbers in this assay, from the lowest: compound 1; then compounds 3 and 4 (each within the scatter of the next). At a limit, above all of these: compound 2.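

Working notes, continued. In this assay the step of a 2.0-fold higher number from compound 3 to compound 4 (0.30 log units; within the scatter) lies within the scatter, so methyl in place of hydrogen on a saturated chain carbon, ten or more bonds along the chain from a sulfur, gives no readable change at this chain length. Octyl in place of hydrogen gives a 4.2-fold higher number from compound 1 to compound 4 (0.63 log units; beyond the scatter), so the longest chain shown stays apart from the shortest, beyond the scatter. Propyl in place of hydrogen gives an at least 5.7-fold lower number from compound 2 to compound 4 (0.76 log units; beyond the scatter), a step read from a limit, so the longest chain does not share the outlying position of the intermediate chain.

How far compound 2 truly departs from the other chains stays open, since its entry is only a limit: the limit of > 100000 nM in this assay, at which 1 of the 4 values shown sits.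

Also open, on these data alone, is how a longer chain, or an amine in place of the chain, would read.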